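From sec-butyl to 2-(methylsulfanyl)ethyl: one side-chain swap

The source may report more compounds than this note shows. Statements on the series, on what has been measured and on what is new or still open speak of the compounds shown alone.

- Compound 1 `CC(C)C[C@H](NC(=O)c1cc(Cl)ccc1OCCNC(=O)OC(C)(C)C)C(=O)Nc1ccc([N+](=O)[O-])cc1Cl`: > 10000 nM
- Compound 2 `CC[C@@H](C)[C@H](NC(=O)c1cc(Cl)ccc1OCCNC(=O)OC(C)(C)C)C(=O)Nc1ccc([N+](=O)[O-])cc1Cl`: 4020 nM

Among the compounds with values here, in a functional assay on MDA-MB-231 cells (Homo sapiens) for inhibition, read by MTT assay, with a stated time of 72 h (a higher number here means a weaker inhibitor, a lower number a stronger inhibitor), compound 2 gives 4020 nM, the only exact number so far. Compound 1 reads > 10000 nM, which is a limit of the assay. Compound 3 `CSCC[C@H](NC(=O)c1cc(Cl)ccc1OCCNC(=O)OC(C)(C)C)C(=O)Nc1ccc([N+](=O)[O-])cc1Cl` makes one change: 2-(methylsulfanyl)ethyl in place of sec-butyl on a saturated chain carbon bound to an amide-type nitrogen and a carbonyl carbon. Within the data shown here, the one measured step at this place, an at least 2.4-fold lower number from compound 1 to compound 2 (0.39 log units; beyond the scatter), was modest, so only a modest step is expected here. The estimated change is a 1.5-fold higher number from compound 2 to compound 3 (0.17 log units; within the scatter), expected to stay within the scatter and lean toward a higher number in this assay. For compound 3 the estimate is 6000 nM, with an expected range of 2500 nM to 16000 nM.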

Compound 3, half-maximal inhibitory concentration: > 10000 nM
Compound 3: only a limit was reported; the forecaster's own chance of this, stated with the estimate: 30%; middle value at least 1.6-fold (0.22 log units) from the limit.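

In this assay, putting 2-(methylsulfanyl)ethyl in place of sec-butyl gives an at least 2.4-fold higher number from compound 2 to compound 3 (0.39 log units; beyond the scatter), so this position responds to a swap even when the heavy-atom count stays the same. Compound 3 reads > 10000 nM, which is a limit of the assay, and the steps that end in two limits cannot be read. Sec-butyl is therefore the only side chain here with an exact number, and the others cannot be ranked: the limit of > 10000 nM in this assay, at which 2 of the 3 values shown sit.

As far as these compounds go, whether an amine, a carboxylic acid or a longer chain at this place would give a lower number than compound 2 stays open.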